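Adding a Second Methoxy Group Where Three Compounds Stay Inactive

The compounds below may be only part of what the source reports. "The series", "measured", "known", "first", "only" and "open" are said of these compounds alone.

Compound 1, `CCOC(=O)c1ccc(Oc2ccc(OC)cc2)cc1`, was tested in a functional assay on HL-60 cells (Homo sapiens) for antiproliferative activity; on this read-out higher numbers stand for weaker inhibition and lower numbers for stronger inhibition. In this assay compound 1 gives > 20000 nM, which is a limit of the assay rather than a number. Compound 2, `CCOC(=O)c1ccc(Oc2ccc(OC)c(OC)c2)cc1`, differs from compound 1 by methoxy in place of hydrogen on an aromatic carbon. In this assay compound 2 gives > 20000 nM, again a limit rather than a number. The resulting change is a step that the two limits leave unreadable from compound 1 to compound 2.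

Compound 3, `COC(=O)c1ccc(Oc2ccc(OC)cc2)c(I)c1`, has a core whose difference from that of compound 1 is not broken down here. In this assay compound 3 gives > 20000 nM, also a limit rather than a number. Taken together, (the limit of > 20000 nM in this assay, at which 3 of the 3 values shown sit).

Compound 4, `COC(=O)c1ccc(Oc2ccc(OC)c(OC)c2)c(I)c1`, has not yet been measured. It differs from compound 3 by methoxy in place of hydrogen on an aromatic carbon, the same change as from compound 1 to compound 2.

The step from compound 3 to compound 4 is expected to be a step that the limit leaves unreadable from compound 3 to compound 4, because the corresponding step that the two limits leave unreadable from compound 1 to compound 2 left both compounds at the limit. Compound 4 is therefore estimated at 30000 nM, most likely reported again only as a limit, with an expected range from 10000 nM to 100000 nM.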

Compound 4, half-maximal inhibitory concentration: 5620 nM
Estimate against measurement, compound 4: 5.3-fold (0.73 log units) above; measured number below the stated range.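

In this assay, adding the second methoxy group to the core of compound 3 gives an at least 3.5-fold lower number from compound 3 to compound 4 (0.55 log units; beyond the scatter), so on this core the change produces a real drop in the number, and the true size of the step may be larger still. The same change on the core of compound 1 gives a step that cannot be read, with compound 1 and compound 2 both left at a limit of the assay, so the data show neither that the effect carries over between the two cores nor that it fails to. Compound 4 is the only compound here with a measured number, which leaves a single readable step and no second one to compare it with: the limit of > 20000 nM in this assay, at which 3 of the 4 values shown sit.

The compounds shown leave open whether an ethoxy group or an amine in place of the new methoxy group would give a similar step on the core of compound 3. They also leave open whether a carboxylic acid in place of the ester would keep the activity of compound 4.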